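Carboxy to ethoxycarbonyl on compound 2

This account rests on a few compounds, and the source may have more. Where it says the series, first, only, none or still open, it means among the compounds named here.

In a functional assay on SK-BR-3 cells (Homo sapiens) for antiproliferative activity, read by MTT assay, with a stated time of 72 h (a higher number here means a weaker inhibitor, a lower number a stronger inhibitor), compound 2 `C/C=C1/[C@H](O[C@@H]2O[C@H](COC(C)=O)[C@@H](OC(C)=O)[C@H](OC(C)=O)[C@H]2OC(C)=O)OC=C(C(=O)OC)[C@H]1CC(=O)O` gives only a limit, > 15000 nM. Compound 1 `C/C=C1/[C@H](O[C@@H]2O[C@H](CO)[C@@H](O)[C@H](O)[C@H]2O)OC=C(C(=O)OC)[C@H]1CC(=O)OCCc1ccc2c(c1)OCCO2` also gives only a limit, > 20000 nM. Compound 3 `C/C=C1/[C@H](O[C@@H]2O[C@H](COC(C)=O)[C@@H](OC(C)=O)[C@H](OC(C)=O)[C@H]2OC(C)=O)OC=C(C(=O)O)[C@H]1CC(=O)O` is likewise a limit, at > 20000 nM. The series therefore offers no true number in this assay, and compound 2 can be placed only at the limit of > 15000 nM in this assay, at which 1 of the 3 values shown sits, with the other two at the limit of > 20000 nM in this assay, at which 2 of the 3 values shown sit.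

Compound 4 `C/C=C1/[C@H](O[C@@H]2O[C@H](COC(C)=O)[C@@H](OC(C)=O)[C@H](OC(C)=O)[C@H]2OC(C)=O)OC=C(C(=O)OC)[C@H]1CC(=O)OCC` comes from compound 2 through one change, ethyl in place of hydrogen on an oxygen next to a carbonyl group: carboxy becomes ethoxycarbonyl.

For the measured compounds named here, the one measured step, also on an oxygen next to a carbonyl group, is a step that the two limits leave unreadable from compound 2 to compound 3. It supplies no size to carry over, so the data support no expected change beyond the scatter and no direction.

The expected result is a step that the limit leaves unreadable from compound 2 to compound 4, and a report as a limit rather than a number is considered likely. For compound 4 the estimated value is 20000 nM, with an expected range of 8000 nM to 40000 nM.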

Compound 4, half-maximal inhibitory concentration: > 15000 nM
Compound 4 was reported as a limit (the forecaster's own chance of this, stated with the estimate: 80%); the middle value is on the limit's open side.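

Compound 2 and compound 4 are both reported only as limits in this assay, so the step between them cannot be read. The compounds shown leave open whether ethyl in place of hydrogen on this oxygen changes the antiproliferative activity at all, as none gives a true number.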